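Amide versus amino link at the carbonyl carbon

A few compounds are considered here, and "the series" means these few. Any claim that something is new, unique, unknown or untested is made for them only; others in the source may bear on it.

Measured compounds:
- compound 1 `COc1cc(-c2nn(-c3cccc(NC(=O)Nc4ccc(Cl)c(Cl)c4)c3)cc2-c2ccncc2)ccc1Cl`: 4470 nM
- compound 2 `COc1cc(-c2nn(-c3cccc(NC(=O)c4ccc(Cl)c(C(F)(F)F)c4)c3)cc2-c2ccncc2)ccc1Cl`: > 32500 nM (a limit, not a number)

In a functional assay on 786-0 cells (Homo sapiens) for inhibition, read by sulforhodamine B assay, with a stated time of 48 h (on this read-out lower numbers stand for stronger inhibition of growth and higher numbers for weaker inhibition of growth), compound 1 gives 4470 nM. Compound 2 reaches only the limit of the assay, > 32500 nM, so its standing is known as a bound and no more (the limit of > 32500 nM in this assay, at which 1 of the 2 values shown sits). Among the measured compounds shown here, the single measured step, an at least 7.2-fold higher number from compound 1 to compound 2 (0.86 log units; beyond the scatter), changes two things at once: the aryl group and the amino link on the carbonyl carbon, so neither change can be weighed on its own.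

Compound 3 `COc1cc(-c2nn(-c3cccc(NC(=O)Nc4ccc(Cl)c(C(F)(F)F)c4)c3)cc2-c2ccncc2)ccc1Cl` differs from compound 2 by (4-chloro-3-(trifluoromethyl)phenyl)amino in place of 4-chloro-3-(trifluoromethyl)phenyl on a carbonyl carbon, which brings back the amino link found in compound 1 while keeping the aryl group of compound 2. For the measured compounds named here, no measured step isolates this change; the only pointer is that compound 1, the one compound carrying the amino link, sits well inside the measured range, whereas compound 2 does not. The expected step is therefore an at least 7.2-fold lower number from compound 2 to compound 3 (0.85 log units; beyond the scatter), a return into the measured range in this assay. Compound 3 is estimated at 4500 nM, with a range from 1500 nM to 15000 nM.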

Compound 3, concentration for total growth inhibition: 8020 nM
Compound 3: middle estimate off by 1.8-fold (0.25 log units), on the low side, and the stated range covers the measured number.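

In this assay, the amino link on the carbonyl carbon can now be read on its own with the aryl group held fixed: (4-chloro-3-(trifluoromethyl)phenyl)amino in place of 4-chloro-3-(trifluoromethyl)phenyl gives an at least 4.0-fold lower number from compound 2 to compound 3 (0.60 log units; beyond the scatter). The size of that step is a bound, since one of its ends is a limit and not a number: the limit of > 32500 nM in this assay, at which 1 of the 3 values shown sits. With the amino link kept, trifluoromethyl in place of chloro on an aromatic carbon gives a 1.8-fold higher number from compound 1 to compound 3 (0.25 log units; within the scatter), so among these three compounds the weak reading of compound 2 goes with the absence of the amino link, not with its aryl group.

Open, on these data alone, is what else the carbonyl carbon accepts: a methylene link, an oxygen link as in a carbamate, or a methylated amino link would show whether the amide hydrogen itself matters or only the length of the linker. Also open, as far as these compounds go, is how far the aryl group can vary with the amino link in place, for instance with a nitrile or a methoxy group in place of trifluoromethyl.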